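Sulfur-bearing chain in place of the bicyclic ether

The compounds below may be only part of what the source reports. "The series", "measured", "known", "first", "only" and "open" are said of these compounds alone.

Compound 1 `Cc1cc(OCc2cccc3nccn23)cc(C)c1-c1cccc(COc2ccc3c(c2)OC[C@H]3CC(=O)O)c1` gives 190 nM in an assay on CHO cells for displacement of a labelled ligand from Free fatty acid receptor 1 (Rattus norvegicus), read by scintillation counting, with a stated time of 90 min, in the presence of a further agent that is not named here (on this read-out higher numbers stand for weaker inhibition and lower numbers for stronger inhibition), the smaller of the two numbers in hand, and compound 2 `Cc1cc(OC2CCS(=O)(=O)CC2)c(F)c(C)c1-c1cccc(COc2ccc3c(c2)OC[C@H]3CC(=O)O)c1` at 270 nM lies within the scatter of that. Compound 3 `CCS(=O)(=O)CCOc1cc(C)c(-c2cccc(COc3ccc4c(c3)OC[C@H]4CC(=O)O)c2)c(C)c1` differs from compound 1 by a group of 6 heavy atoms (3 carbon, 2 oxygen, 1 sulfur; no ring) in place of a group of 9 heavy atoms (7 carbon, 2 nitrogen; one five-membered aromatic ring with 2 hetero atoms, one six-membered aromatic ring with 1 hetero atom), on a saturated chain carbon bound to an oxygen on an aromatic ring. For the measured compounds named here, no step between measured compounds is known, so no move beyond the scatter is expected in this assay. Compound 3 is expected at 300 nM, range 120 nM to 750 nM, an estimated step of a 1.6-fold higher number from compound 1 to compound 3 (0.20 log units; within the scatter).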

Compound 3, inhibition constant: 170 nM
The estimate for compound 3 lay 1.8-fold (0.25 log units) above the measured number, within the range that was stated.
By their numbers in this assay, from the lowest: compounds 3, 1 and 2 (each within the scatter of the next).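

On the saturated chain carbon bound to an oxygen on an aromatic ring, the ring-free (ethylsulfonyl)methyl and the group of two aromatic rings are not told apart in this assay: the exchange gives a 1.1-fold lower number from compound 1 to compound 3 (0.05 log units; within the scatter). At this place, therefore, neither the aromatic rings nor the nitrogens of the leaving group are needed to keep the number within the scatter of compound 1. Nothing in hand explains this result.

From the compounds shown here alone, whether an amine or a sulfonamide on this chain carbon stays in the same range remains open. So does whether any group here moves the number beyond the scatter.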